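This account rests on a few compounds, and the source may have more. Where it says the series, first, only, none or still open, it means among the compounds named here.

In a functional assay (Homo sapiens) for antiproliferative activity, read by sulforhodamine B assay, with a stated time of 48 h (on this read-out higher numbers stand for weaker inhibition and lower numbers for stronger inhibition), compound 1 (`Cc1cccc(NS(=O)(=O)c2ccc(N3CCNC3=O)cc2)c1`) gives 290 nM and compound 2 (`O=C1NCCN1c1ccc(S(=O)(=O)Nc2cccc(Br)c2)cc1`) gives 270 nM with no separation between them. Compound 3 (`Cc1ccc(C)c(NS(=O)(=O)c2ccc(N3CCNC3=O)cc2)c1`) gives 86 nM as the lowest of the three numbers, beyond the scatter from both others. Compound 4 (`O=C1NCCN1c1ccc(S(=O)(=O)Nc2cccc(Cl)c2)cc1`) differs from compound 3 as follows: 3-chlorophenyl in place of 2,5-dimethylphenyl on a sulfonamide nitrogen. The step bearing most closely involves 3-bromophenyl (a 3.1-fold lower number from compound 2 to compound 3 (0.50 log units; beyond the scatter)). The added methyl gives a step of like size (a 3.4-fold lower number from compound 1 to compound 3 (0.53 log units; beyond the scatter)), while bromo for methyl stays within the scatter (a 1.1-fold lower number from compound 1 to compound 2 (0.03 log units; within the scatter)). A modest rise in the number is therefore expected in this assay (a 3.3-fold higher number from compound 3 to compound 4 (0.51 log units; beyond the scatter)). Compound 4 is estimated at 280 nM (range 130 nM to 600 nM).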

Compound 4, half-maximal inhibitory concentration: 190 nM
The estimate for compound 4 lay 1.5-fold (0.17 log units) above the measured number; the measured number falls inside the stated range.
By their numbers in this assay, from the lowest: compound 3; then compounds 4, 2 and 1 (each within the scatter of the next).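

In this assay chloro in place of bromo stays within the scatter (a 1.4-fold lower number from compound 2 to compound 4 (0.15 log units; within the scatter)), as does chloro in place of methyl (a 1.5-fold lower number from compound 1 to compound 4 (0.18 log units; within the scatter)), so compounds 1, 2 and 4 form one level whichever of these three groups is present. The change from 2,5-dimethylphenyl to 3-chlorophenyl on the sulfonamide nitrogen (a 2.2-fold higher number from compound 3 to compound 4 (0.34 log units; beyond the scatter)) leaves compound 3 alone, beyond the scatter from each of the others. No measurement available here explains these steps.

Still open, going by these compounds, is whether the lower number of compound 3 holds with a methoxy group, an amine or a carboxylic acid on this phenyl ring.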